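Fluoro Added to the Methylsulfonyl Arm of Compound 3

The compounds below may be only part of what the source reports. "The series", "measured", "known", "first", "only" and "open" are said of these compounds alone.

Measured compounds:
compound 1 `COCc1ccc(F)c(C#Cc2cc(Cl)ccc2OCC(=O)O)c1` — 72 nM
compound 2 `O=C(O)COc1ccc(Cl)cc1C#Cc1cc(CO)ccc1F` — 73 nM
compound 3 `CS(=O)(=O)c1cccc(C#Cc2cc(Cl)ccc2OCC(=O)O)c1` — 15 nM

All three numbers come from an assay on CHO cells for displacement of a labelled ligand from prostaglandin D2 receptor 2 (Homo sapiens), read by scintillation counting; on this read-out lower numbers stand for stronger inhibition and higher numbers for weaker inhibition. Compound 3 stands lowest of the three; compound 1 is its nearest neighbour and compound 2 its furthest, both gaps beyond the scatter. Among the measured compounds shown here, the only single-point step among the measured compounds is a 1.0-fold higher number from compound 1 to compound 2 (0.01 log units; within the scatter), a change at the oxygen on a saturated carbon that says nothing about substitution on an aromatic ring.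

Compound 4 `CS(=O)(=O)c1ccc(F)c(C#Cc2cc(Cl)ccc2OCC(=O)O)c1` differs from compound 3 by fluoro in place of hydrogen on an aromatic carbon: on an aromatic carbon of a six-membered aromatic ring of carbon only, ortho to a large group and para to a methylsulfonyl group. For the measured compounds named here, no measured pair isolates a fluoro-for-hydrogen exchange. Compounds 1 and 2 carry a fluoro on their own arm, but they differ from compound 3 in more than one place, so their values show only that their arms give higher numbers than the methylsulfonyl arm of compound 3.

Going by the values given here, with no direct precedent, the step to compound 4 is expected to stay within the scatter, no change at the digits printed from compound 3 to compound 4 (within the scatter). Compound 4 is accordingly estimated at 15 nM, with a range of 6 nM to 40 nM.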

Compound 4, inhibition constant: 3.3 nM
Beside the measured number, compound 4's estimate is 4.5-fold (0.66 log units) above it; the whole stated range lies above it.
By their numbers in this assay, from the lowest: compound 4; then compound 3; then compounds 1 and 2 (each within the scatter of the next).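

The fluoro, on an aromatic carbon ortho to a large group and para to a methylsulfonyl group, gives in this assay the first isolated read of an exchange on this ring: a 4.5-fold lower number from compound 3 to compound 4 (0.66 log units; beyond the scatter). Among the compounds shown here, with the fluoro present on all three compounds, the methylsulfonyl group can also be set against the other two groups in single steps, which the earlier compounds did not allow: a 22-fold lower number from compound 2 to compound 4 (1.34 log units; beyond the scatter) for hydroxymethyl and a 22-fold lower number from compound 1 to compound 4 (1.34 log units; beyond the scatter) for methoxymethyl. So both the fluoro and the methylsulfonyl group count here, and compound 4 stands lowest of the four.

Open, going by these compounds, is whether a nitrile or trifluoromethyl in place of the fluoro would give a similar step, and whether the fluoro step would hold with a different group at the para place. Nothing shown here gives a reason for any of these steps.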